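Acrylamide to chloroacetamide swap on two phenoxyphenyl pyrazole cores

This account rests on a few compounds, and the source may have more. Where it says the series, first, only, none or still open, it means among the compounds named here.

Compound 1 `C=CC(=O)N1CCCC(n2nc(-c3ccc(Oc4ccccc4)cc3)cc2C(=O)OCC)C1` and compound 3 `CCOC(=O)c1cc(-c2ccc(Oc3ccccc3)cc2)nn1C1CCCN(C(=O)CCl)C1` share one core and differ in one place: chloromethyl in place of vinyl on a carbonyl carbon In a functional assay on JeKo-1 cells (Homo sapiens) for inhibition, read by luminescence and CellTiter-Glo, with a stated time of 72 h (a lower number here means a stronger inhibitor, a higher number a weaker inhibitor), compound 1 gives 21200 nM, while compound 3 gives 800 nM; the step is a 27-fold lower number from compound 1 to compound 3 (1.42 log units; beyond the scatter). Compound 2 `C=CC(=O)Nc1cccc(Cn2nc(-c3ccc(Oc4ccccc4)cc3)cc2CO)c1` is built on a different core; the difference between the two cores is not broken down here. In this assay compound 2 gives 5200 nM, which stands between the other two measured values, further from compound 3 than from compound 1.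

Compound 4 `O=C(CCl)Nc1cccc(Cn2nc(-c3ccc(Oc4ccccc4)cc3)cc2CO)c1` has not yet been measured. It relates to compound 2 as compound 3 relates to compound 1: chloromethyl in place of vinyl on a carbonyl carbon The place is not identical word for word: in compound 1 the carbonyl carbon sits on an amide-type nitrogen in a ring, whereas in compound 2 it sits on an amide-type nitrogen that is not in a ring, so this is the same kind of change rather than the same change.

Going by the values given here, the expectation for compound 4 rests on the one measured instance of this change, and the step is expected to be an 8.7-fold lower number from compound 2 to compound 4 (0.94 log units; beyond the scatter), set smaller than the measured one because the step of a 27-fold lower number from compound 1 to compound 3 (1.42 log units; beyond the scatter) was seen on a different core and around a different nitrogen, and a single instance gives no assurance that its full size carries over. On that basis compound 4 is estimated at 600 nM in this assay, with a plausible range from 150 nM to 2500 nM.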

Compound 4, half-maximal inhibitory concentration: 400 nM
Estimate against measurement, compound 4: 1.5-fold (0.18 log units) above; measured number inside the range.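

In this assay the swap of vinyl for chloromethyl on a carbonyl carbon gives a 13-fold lower number from compound 2 to compound 4 (1.11 log units; beyond the scatter), so the drop seen on the core of compound 1 recurs on the core of compound 2, with the carbonyl on an amide-type nitrogen that is not in a ring as well as on one that is. The two steps run the same way and cannot be told apart in size: the same change on two cores in this assay, a 27-fold lower number (1.42 log units; beyond the scatter) from compound 1 to compound 3 and a 13-fold lower number (1.11 log units; beyond the scatter) from compound 2 to compound 4, 2.0-fold (0.31 log units) apart, within the scatter of two such steps. Going by these compounds alone, this rests on only two cores and one read-out, so it supports carrying the change between these two cores but sets no rule for other cores, and it does not show why the number falls or whether it would fall in any other test.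

Left open is whether another group on the same carbonyl carbon, such as bromomethyl or a longer chain, would follow chloromethyl or vinyl on these cores. Also open, on these data alone, is whether the step keeps its size when the ethyl ester of compound 1 or the hydroxymethyl of compound 2 gives way to a carboxylic acid or an amine.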